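Benzothiazole in Place of Methylthiazole on the Amide

The compounds below may be only part of what the source reports. "The series", "measured", "known", "first", "only" and "open" are said of these compounds alone.

Measured so far:
- compound 1, `COc1ccc(-c2cn(CC(=O)Nc3nc4ccccc4s3)nn2)cc1`: 1330 nM
- compound 2, `COC(=O)c1ccc(-c2cn(CC(=O)Nc3nc(C)cs3)nn2)cc1`: > 30000 nM

In a functional assay on BMDM cells (Mus musculus, strain C57BL/6) for inhibition, with a stated time of 2 days (a lower number here means a stronger inhibitor, a higher number a weaker inhibitor), compound 1 gives 1330 nM. Compound 2 is reported only as a limit of this assay, > 30000 nM, so no number is known for it; it sits at the limit of > 30000 nM in this assay, at which 1 of the 2 values shown sits, the weaker end of what has been measured here. The two compounds differ in more than one place, so their values can only be set side by side, not read as a single step.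

Compound 3, `COC(=O)c1ccc(-c2cn(CC(=O)Nc3nc4ccccc4s3)nn2)cc1`, has not yet been measured in this assay. Compared with compound 2 it carries 1,3-benzothiazol-2-yl in place of 4-methyl-1,3-thiazol-2-yl on an amide-type nitrogen. For the measured compounds named here, the 1,3-benzothiazol-2-yl group is the one found in compound 1, whose value is 1330 nM. Since compound 2 is only a limit, the size of the step cannot be pinned down; the expectation is that compound 3 moves from compound 2 toward a measurable number, as an at least 5.0-fold lower number from compound 2 to compound 3 (0.69 log units; beyond the scatter). Compound 3 is therefore expected to give about 6000 nM in this assay, within a range from 1500 nM to 30000 nM.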

Compound 3, half-maximal inhibitory concentration: > 30000 nM
Compound 3 was reported as a limit; the forecaster's own chance of this, stated with the estimate: 30%; middle value at least 5.0-fold (0.69 log units) from the limit.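

In this assay, keeping 1,3-benzothiazol-2-yl on the amide-type nitrogen and placing methoxycarbonyl instead of methoxy on the aromatic carbon gives an at least 22-fold higher number from compound 1 to compound 3 (1.35 log units; beyond the scatter). This shows that 1,3-benzothiazol-2-yl does not by itself bring a measurable value in this assay, and that the group on the aromatic carbon matters a great deal when this amide group is present. Compound 2 and compound 3 are both reported only as limits, so the step between them cannot be read, and both methoxycarbonyl compounds end up at the same limit: the limit of > 30000 nM in this assay, at which 2 of the 3 values shown sit.

The compounds shown leave open how far past the limit compound 2 and compound 3 lie, and whether 4-methyl-1,3-thiazol-2-yl on the amide-type nitrogen would give a measurable value alongside methoxy on the aromatic carbon. They also leave open how other groups on that aromatic carbon, such as a carboxylic acid or an amine, would read in this assay.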